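Phenyl for propyl on the isoxazole: expected cytotoxicity

The source may report more compounds than this note shows. Statements on the series, on what has been measured and on what is new or still open speak of the compounds shown alone.

Measured compounds:
compound 1 `CC(=O)OC[C@H]1O[C@@H](n2cc(-c3cc(C)no3)c(=O)[nH]c2=O)C[C@@H]1OC(C)=O`, 3000 nM
compound 2 `CCCc1cc(-c2cn([C@H]3C[C@H](OC(C)=O)[C@@H](COC(C)=O)O3)c(=O)[nH]c2=O)on1`, 3000 nM

In an ADME assay on MT4 cells (Homo sapiens) for cytotoxicity (a higher number here means that more compound is tolerated, a lower number that less compound is tolerated), compound 2 gives 3000 nM, level with compound 1 at the digits shown. For the measured compounds named here, the one measured step, no change at the digits printed from compound 1 to compound 2 (within the scatter), lies within the scatter. Compound 3 `CC(=O)OC[C@H]1O[C@@H](n2cc(-c3cc(-c4ccccc4)no3)c(=O)[nH]c2=O)C[C@@H]1OC(C)=O` differs from compound 2 by phenyl in place of propyl on an aromatic carbon. Going by the values given here, no measured step covers this change; the only step available altered the same chain by a smaller group and moved nothing. Compound 3 is therefore expected to stay level, no change at the digits printed from compound 2 to compound 3 (within the scatter), with an estimate of 3000 nM, between 1500 nM and 6000 nM.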

Compound 3, half-maximal cytotoxic concentration: 3000 nM
Compound 3: middle estimate and measured number agree at the digits printed, and the stated range covers the measured number.
By their numbers in this assay, from the lowest: compounds 1, 2 and 3 (each within the scatter of the next).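

In this assay, the aromatic carbon next to the ring nitrogen accepts a six-membered aromatic ring as readily as a saturated chain: phenyl for propyl gives no change at the digits printed from compound 2 to compound 3 (within the scatter) and phenyl for methyl gives no change at the digits printed from compound 1 to compound 3 (within the scatter) as well. The flat reading therefore now spans a ring and not only chains of differing length at this position. No evidence is available to explain this lack of movement.

Going by these compounds, whether an amine, a carboxylic acid or a substituted phenyl at this position would shift the reading remains open. So does the effect of replacing the two acetate esters on the shared core.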